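Swapping 4-hydroxyphenyl for 2-methylphenyl in compound 4

The source may hold more compounds than are shown below. What is called first, only, known or untested is meant among the compounds shown, and "the series" means these compounds.

compound 1 `COC1=C(C)C(=O)/C(=C(O)/C=C/c2ccc(Br)cc2)C(=O)C1(C)C` gives 1.7 ug/mL
compound 2 `COC1=C(C)C(=O)/C(=C(O)/C=C/c2ccc(O)cc2)C(=O)C1(C)C` gives 3.8 ug/mL
compound 3 `COC1=C(C)C(=O)/C(=C(O)/C=C/c2ccc(C)cc2)C(=O)C1(C)C` gives 3.9 ug/mL

In a functional assay on KB cells (Homo sapiens) for cytotoxicity (on this read-out higher numbers stand for an effect only at larger amounts of compound and lower numbers for an effect already at smaller amounts), compound 2 gives 3.8 ug/mL as a number within the scatter of compound 3 and higher than that of compound 1. Compound 4 `COC1=C(C)C(=O)/C(=C(O)/C=C/c2ccccc2C)C(=O)C1(C)C` is still unmeasured. It differs from compound 2 by 2-methylphenyl in place of 4-hydroxyphenyl on a double-bonded chain carbon bound to a double-bonded chain carbon with 2-methylphenyl in place of 4-hydroxyphenyl on a double-bonded chain carbon bound to a double-bonded chain carbon. The nearest measured change is a 1.0-fold higher number from compound 2 to compound 3 (0.01 log units; within the scatter) for methyl in place of hydroxy on an aromatic carbon. Replacing bromo gave a 2.2-fold higher number from compound 1 to compound 2 (0.35 log units; beyond the scatter) and a 2.3-fold higher number from compound 1 to compound 3 (0.36 log units; beyond the scatter) as modest steps. For the measured compounds named here, no measured compound carries 2-methylphenyl, so this guide is only partial. No step beyond the scatter is expected, and the estimated step is a 1.1-fold lower number from compound 2 to compound 4 (0.02 log units; within the scatter) in size. For compound 4 the expected value is 3.6 ug/mL with 1.6 ug/mL as the estimated lower end and 8 ug/mL as the upper end.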

Compound 4, concentration for half-maximal effect: 4.1 ug/mL
For compound 4 the middle estimate is 1.1-fold (0.06 log units) below the measured one, within the range that was stated.
By their numbers in this assay, from the lowest: compound 1; then compounds 2, 3 and 4 (each within the scatter of the next).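

In this assay the change to 2-methylphenyl on this double-bonded chain carbon gives a 1.1-fold higher number from compound 3 to compound 4 (0.02 log units; within the scatter) and a 1.1-fold higher number from compound 2 to compound 4 (0.03 log units; within the scatter) so moving the methyl from 4-methylphenyl to 2-methylphenyl has no readable effect here. The 4-bromophenyl compound alone stays apart with a 2.4-fold higher number from compound 1 to compound 4 (0.38 log units; beyond the scatter) as the step to this group. Nothing available explains these results. The compounds shown leave open whether an amine or a carboxylic acid on the aromatic ring would shift the number, and whether 2-bromophenyl would match compound 1.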